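A few compounds are considered here, and "the series" means these few. Any claim that something is new, unique, unknown or untested is made for them only; others in the source may bear on it.

Of the compounds shown here, two with a shared core have been measured in a functional assay on NCI-H1581 cells (Homo sapiens) for inhibition, read by MTT assay, with a stated time of 48 h, tested at 10 uM; on this read-out higher numbers stand for more inhibition at the one concentration tested (going by the name of the read-out) and lower numbers for less inhibition. Compound 1, `CCc1ccc(Nc2cc(NC(=O)Nc3cc(OC)cc(OC)c3)ncn2)cc1`, gives 32.7% in this assay. Compound 2, `COc1cc(NC(=O)Nc2cc(Nc3cccc(C(C)(C)C)c3)ncn2)cc(OC)c1`, gives 35.1% in this assay. The one step between them, a number 2.4 percentage points higher from compound 1 to compound 2 (within the scatter), changes only the group on the nitrogen-bound phenyl ring, and on the two numbers shown compound 2 stands at the top, with compound 1 the nearest and within the scatter of it, so the two cannot be ranked against each other.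

Compound 3, `CCc1cccc(Nc2cc(NC(=O)Nc3cc(OC)cc(OC)c3)ncn2)c1`, has not been measured. It differs from compound 2 by ethyl in place of tert-butyl on an aromatic carbon, so the swap is from 3-(tert-butyl)phenyl to 3-ethylphenyl, on an aromatic carbon of a six-membered aromatic ring of carbon only, meta to a large group.

For the measured compounds named here, the only step that bears on this change is a number 2.4 percentage points higher from compound 1 to compound 2 (within the scatter), which also altered the group on that same phenyl ring, from 4-ethylphenyl to 3-(tert-butyl)phenyl, and moved the number within the scatter. Since the ethyl group already appeared on compound 1 at 32.7% without a visible difference from compound 2, the estimated step of a number 2.1 percentage points lower from compound 2 to compound 3 (within the scatter) is expected to stay within the scatter. Compound 3 is therefore estimated at 33% in this assay, expected between 20% and 46%.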

Compound 3, a percentage reported as inhibition, at one concentration (the size of the read-out at that concentration, not a potency): 27.7%
The estimate for compound 3 lay 5.3 percentage points above the measured number; low and high end bracket the measured number.
By their numbers in this assay, from the lowest: compounds 3, 1 and 2 (each within the scatter of the next).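

In this assay, ethyl in place of tert-butyl on an aromatic carbon of the six-membered aromatic ring gives a number 7.4 percentage points lower from compound 2 to compound 3 (within the scatter), so at this position the number does not tell these two groups apart, even though the change removes two of the four carbons of tert-butyl. For the compounds shown here, the 3-ethylphenyl in place of 4-ethylphenyl gives a number 5 percentage points lower from compound 1 to compound 3 (within the scatter), which is the first direct test of where the ethyl group sits on the ring, and the two placements cannot be ranked on this read-out. Nothing measured alongside these numbers speaks to what lies behind them.

From the compounds shown here alone, all three compounds carry only a carbon-and-hydrogen group on this ring, and all their numbers lie within the scatter of the next, so it remains open whether an amine, a carboxylic acid or a longer chain at the same position would give a clearly different number. The rest of the shared core is the same in all three compounds, so these comparisons say nothing about changes made there.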